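Taking one methoxy away from compound 3

The source may hold more compounds than are shown below. What is called first, only, known or untested is meant among the compounds shown, and "the series" means these compounds.

Three related compounds have been measured in a functional assay on MCF7 cells (Homo sapiens) for antiproliferative activity, read by MTT assay, with a stated time of 48 h; a lower number here means a stronger inhibitor, a higher number a weaker inhibitor. Compound 1 `Oc1ccc2ccccc2c1C(Nc1nc2ccccc2s1)c1cn(-c2ccccc2)nc1-c1ccccc1` gives 48900 nM, compound 2 `COc1cccc(-c2nn(-c3ccccc3)cc2C(Nc2nc3ccc(OC)cc3s2)c2c(O)ccc3ccccc23)c1` gives 62600 nM, and compound 3 `COc1cccc(-c2nn(-c3ccccc3)cc2C(Nc2nc3ccc(Cl)cc3s2)c2c(O)ccc3ccccc23)c1` gives 36000 nM. Compound 3 therefore sits within the usual scatter of both neighbours, so these numbers do not rank the three compounds.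

The next compound makes one small change. Compound 4 `Oc1ccc2ccccc2c1C(Nc1nc2ccc(Cl)cc2s1)c1cn(-c2ccccc2)nc1-c1ccccc1` differs from compound 3 by hydrogen in place of methoxy on an aromatic carbon, so that 3-methoxyphenyl becomes phenyl.

Among the compounds with values here, no measured step makes exactly this change. The closest evidence is a 1.7-fold lower number from compound 2 to compound 3 (0.24 log units; within the scatter), where chloro replaces methoxy elsewhere in the molecule, and that step lies within the scatter. Compound 1 also carries the plain phenyl, though it lacks the chloro, and it gives 48900 nM, a value within the scatter of compound 3. Within the data shown here, nothing measured so far therefore points to a large effect from losing this methoxy, and no direction can be expected with confidence.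

The expected result is a 1.1-fold higher number from compound 3 to compound 4 (0.02 log units; within the scatter), which would be no real change beyond the scatter. Compound 4 is estimated at 38000 nM, with an expected range from 19000 nM to 75000 nM.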

Compound 4, half-maximal inhibitory concentration: 36300 nM
The estimate for compound 4 lay 1.0-fold (0.02 log units) above the measured number, and the stated range covers the measured number.
By their numbers in this assay, from the lowest: compounds 3, 4, 1 and 2 (each within the scatter of the next).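

In this assay, swapping the methoxy for hydrogen, so that 3-methoxyphenyl becomes phenyl, gives a 1.0-fold higher number from compound 3 to compound 4 (0.00 log units; within the scatter). Within the data shown here, this is the first direct reading of this change, and it shows that, with chloro present on the shared core, the methoxy at this position can be lost with no change beyond the scatter. The chloro also gets a reading with the plain phenyl in place, with hydrogen changing to chloro giving a 1.3-fold lower number from compound 1 to compound 4 (0.13 log units; within the scatter), so neither single change among these compounds moves the number beyond the scatter, and no measurement here offers an explanation for these results.

Among these compounds, what stays open is whether this position matters at all in this assay, since a hydrogen and a methoxy are only two of the many groups it could carry. An amine, a carboxylic acid or a longer chain such as butoxy on this same aromatic carbon would test whether any group there can move the number beyond the scatter, in either direction.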